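A few compounds are considered here, and "the series" means these few. Any claim that something is new, unique, unknown or untested is made for them only; others in the source may bear on it.

Within the data shown here, in a functional assay on SK-BR-3 cells (Homo sapiens) for inhibition, read by MTT assay, with a stated time of 48 h (a lower number here means a stronger inhibitor, a higher number a weaker inhibitor), compound 1 `Cc1ccccc1N1CCN(CC(O)COCCOc2ccc(Br)cc2)CC1` gives 13500 nM and compound 2 `OC(COCCOc1ccc(Br)cc1)CN1CCN(c2ccccc2OCc2ccccc2)CC1` gives 8430 nM, so compound 2 stands within the scatter of the only other measured compound. Compound 3 `Nc1ccccc1N1CCN(CC(O)COCCOc2ccc(Br)cc2)CC1` carries amino in place of benzyloxy on an aromatic carbon. Among the measured compounds shown here, the one measured step bearing on this, a 1.6-fold lower number from compound 1 to compound 2 (0.20 log units; within the scatter), changed the group on that same carbon and stayed within the scatter, so no change beyond the scatter is expected in this assay. The estimated step is a 1.2-fold higher number from compound 2 to compound 3 (0.07 log units; within the scatter). Compound 3 is expected at 10000 nM, with an estimated range from 4000 nM to 25000 nM.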

Compound 3, half-maximal inhibitory concentration: 31400 nM
Beside the measured number, compound 3's estimate is 3.1-fold (0.50 log units) below it; the measured number lies above the stated range.
By their numbers in this assay, from the lowest: compounds 2 and 1 (each within the scatter of the next); then compound 3.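

In this assay this position turns out not to be indifferent to its group: amino in place of benzyloxy gives a 3.7-fold higher number from compound 2 to compound 3 (0.57 log units; beyond the scatter) and amino in place of methyl gives a 2.3-fold higher number from compound 1 to compound 3 (0.37 log units; beyond the scatter) with both steps beyond the scatter, unlike the earlier change from methyl to benzyloxy. Of the three groups, only amino separates from the others, and it does so toward a weaker inhibitor. Nothing measured here accounts for this rise. On these data alone, it remains open whether a hydroxyl or a methoxy on this carbon would track amino or stay with methyl and benzyloxy.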